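Cytotoxicity notes: cyclohexyl in place of tert-butyl

The source may hold more compounds than are shown below. What is called first, only, known or untested is meant among the compounds shown, and "the series" means these compounds.

Measured so far, read in a functional assay on BeWo cells (Homo sapiens) for cytotoxicity, read by MTT assay, with a stated time of 72 h; on this read-out lower numbers stand for stronger inhibition and higher numbers for weaker inhibition:
compound 1, `O=[N+]([O-])c1ccc(-c2nnc3nnc(N4CCCCC4)n3n2)cc1`: > 100000 nM
compound 2, `CC(C)(C)c1nnc2nnc(N3CCCC3)nn12`: 12500 nM
compound 3, `Clc1ccc(-c2nnc3nnc(N4CCCC4)nn23)c(Cl)c1`: 8060 nM

Among the compounds with values here, the value of compound 1 is a limit of the assay and not a number; it is the one reading at the limit of > 100000 nM in this assay, at which 1 of the 3 values shown sits. Among the two numbers, compound 2 has the higher one. Compound 3 sits close to it, and the gap between compound 2 and compound 3 lies within the usual scatter, so the two are read as alike, with no order between them. Within the data shown here, no pair of measured compounds differs in one place only, so no measured step stands behind this series.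

Compound 4, `C1CCC(c2nnc3nnc(N4CCCC4)nn23)CC1`, is yet to be measured in this assay. It differs from compound 2 in one place: cyclohexyl in place of tert-butyl on an aromatic carbon. Nothing measured here shows what this change does to the read-out. The expectation is therefore a step from compound 2 to compound 4 of no size beyond the scatter, in either direction, written as a 1.1-fold lower number from compound 2 to compound 4 (0.06 log units; within the scatter). On that basis compound 4 is expected to give about 11000 nM in this assay, with a range from 3500 nM to 35000 nM.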

Compound 4, half-maximal inhibitory concentration: 22000 nM
Estimate against measurement, compound 4: 2.0-fold (0.30 log units) below, and the stated range covers the measured number.
By their numbers in this assay, from the lowest: compounds 3, 2 and 4 (each within the scatter of the next, the first and the last beyond it). At a limit, above all of these: compound 1.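

In this assay, within the data shown here, cyclohexyl in place of tert-butyl on an aromatic carbon gives a 1.8-fold higher number from compound 2 to compound 4 (0.25 log units; within the scatter) and this is the first step with only one place changed. The position, on an aromatic carbon of a five-membered aromatic ring and between two ring nitrogen atoms, therefore takes a six-membered non-aromatic ring of carbon only in place of tert-butyl with the read-out staying within the scatter, so compound 2 and compound 4 are read as alike and this one step gives no sign that the choice between these two groups matters here. Nothing at hand gives a cause for this step.

From the compounds shown here alone, both groups at this position are made of carbon only and carry no hydrogen-bond donors or acceptors, so what a primary amine, a carboxylic acid or a smaller group such as methyl would do at the same place stays open. Also open, going by these compounds, is whether the same change would give a like step if a morpholine stood in place of the ring amine shared by compound 2 and compound 4.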